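Amide aryl change from compound 2 to compound 4

The compounds below may be only part of what the source reports. "The series", "measured", "known", "first", "only" and "open" are said of these compounds alone.

Three members of the series have been measured in a functional assay on A549 cells (Homo sapiens) for inhibition, read by MTT assay, with a stated time of 24 h; a lower number here means a stronger inhibitor, a higher number a weaker inhibitor. Compound 1 `CCOC(=O)C1=Cc2ccccc2OC1(OCc1cc(-c2ccc(F)cc2F)no1)C(F)(F)F` returns only a limit, > 150000 nM. Compound 3 `CCOC(=O)C1=Cc2ccccc2OC1(OCc1cc(-c2ccc([N+](=O)[O-])cc2)no1)C(F)(F)F` likewise returns a limit, > 150000 nM. The step that the two limits leave unreadable from compound 1 to compound 3 is therefore unreadable, as both ends sit at the limit of > 150000 nM in this assay, at which 2 of the 3 values shown sit. Among the compounds with values here, compound 2 `CCOC(=O)C1=Cc2ccccc2OC1(OCc1cn(CC(=O)Nc2cccc(Cl)c2)nn1)C(F)(F)F` is the only member with a number: in this assay compound 2 gives 12800 nM, so it stands alone as the single readable point.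

Compound 4 `CCOC(=O)C1=Cc2ccccc2OC1(OCc1cn(CC(=O)Nc2ccc(I)cc2Cl)nn1)C(F)(F)F` is not yet measured. It differs from compound 2 in one place: 2-chloro-4-iodophenyl in place of 3-chlorophenyl on an amide-type nitrogen. Within the data shown here, no measured step touches this part of the molecule; the only step in hand, a step that the two limits leave unreadable from compound 1 to compound 3, concerns a different arm, the one carried by compound 1 and compound 3, and gives no size. There is thus no basis for expecting a step beyond the scatter. The step of a 1.3-fold lower number from compound 2 to compound 4 (0.11 log units; within the scatter) is expected to stay small, within the usual scatter. Compound 4 is estimated at 10000 nM, with a range from 3500 nM to 35000 nM.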

Compound 4, half-maximal inhibitory concentration: 22300 nM
Compound 4: middle estimate off by 2.2-fold (0.35 log units), on the low side; low and high end bracket the measured number.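

In this assay, within the data shown here, the amide aryl position now has a step of readable size, a 1.7-fold higher number from compound 2 to compound 4 (0.24 log units; within the scatter), whereas the only earlier step, on a different arm, had none. The exchange of 3-chlorophenyl for 2-chloro-4-iodophenyl on the amide-type nitrogen brings in an iodine and still leaves compound 2 and compound 4 indistinguishable, so this change gives no sign that the position governs the read-out. No measurement shown accounts for the step.

Both aryl groups shown here are halogenated phenyl rings, so it remains open whether a phenyl ring bearing an amine or a carboxylic acid, or a cyclohexyl group in its place, would move the number beyond the scatter. The arm of compound 1 and compound 3 gives limits only, and its step cannot be read.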